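Trifluoromethyl in Place of Methyl on an Inactive Pair

This account rests on a few compounds, and the source may have more. Where it says the series, first, only, none or still open, it means among the compounds named here.

Compound 1 `Cc1ccc(C(O)c2cn(CC3COC(C)(C)O3)nn2)cc1`: in a functional assay on B16 cells (Mus musculus) for cytotoxicity, read by MTT assay, with a stated time of 48 h (a higher number here means a weaker inhibitor, a lower number a stronger inhibitor), compound 1 gives > 100000 nM, which is a limit of the assay.
Compound 2 `Cc1ccc(C(O)c2cn(C[C@H]3COC(C)(C)O3)nn2)cc1`: in this assay compound 2 gives > 100000 nM, again a limit of the assay.

Among the measured compounds shown here, compound 1 therefore stands only at a limit in this assay, and the single further value shown is a limit as well. For the measured compounds named here, the one measured step, a step that the two limits leave unreadable from compound 1 to compound 2, cannot be read, since the limit of > 100000 nM in this assay, at which 2 of the 2 values shown sit, leaves its size hidden; the step concerns only (the fact that one of compounds 1 and 2 is drawn with a defined configuration and the other without, at the place where they differ), not a change of atoms. Compound 3 `CC1(C)OCC(Cn2cc(C(O)c3ccc(C(F)(F)F)cc3)nn2)O1` differs from compound 1 by trifluoromethyl in place of methyl on an aromatic carbon. Going by the values given here, no measured step bears on that exchange, so nothing beyond the scatter is expected in this assay in either direction. For compound 3 the estimate is 100000 nM with a range of 30000 nM to 300000 nM. The step from compound 1 to compound 3 is estimated as a number no higher from compound 1 to compound 3 (the limit leaves the size open), with a limit again the most likely outcome.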

Compound 3, half-maximal inhibitory concentration: > 100000 nM
Compound 3 gave a limit, no number (the forecaster's own chance of this, stated with the estimate: 80%); the middle value sits exactly at the limit.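

The step from compound 1 to compound 3 cannot be read, as both values are limits of the assay in this assay: the limit of > 100000 nM in this assay, at which 3 of the 3 values shown sit.

The compounds shown leave open whether trifluoromethyl in place of methyl on an aromatic carbon changes anything in this assay, and how strong any of the three compounds actually is.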